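Substitution on the ring nitrogen of compound 1

A few compounds are considered here, and "the series" means these few. Any claim that something is new, unique, unknown or untested is made for them only; others in the source may bear on it.

Measured compounds in a functional assay on CHO cells for antagonist activity at C-C chemokine receptor type 4 (Homo sapiens), read by radioligand binding and GTPgammaS binding; on this read-out higher numbers stand for weaker inhibition and lower numbers for stronger inhibition:
compound 1 `COc1cc2[nH]c(=O)[nH]c2cc1NS(=O)(=O)c1cccc(Cl)c1Cl` gives 316 nM
compound 2 `COc1cc2c(cc1NS(=O)(=O)c1cccc(Cl)c1Cl)[nH]c(=O)n2C(CO)CO` gives 1580 nM
compound 3 `COc1cc2c(cc1NS(=O)(=O)c1cccc(Cl)c1Cl)[nH]c(=O)n2C1CN(C(C)=O)C1` gives 200 nM

Compound 1, carrying a hydrogen on the ring nitrogen, stands second highest of the three numbers in this assay. Its nearest neighbour is compound 3, the step of a 1.6-fold lower number from compound 1 to compound 3 (0.20 log units; within the scatter) lying within the scatter. Its furthest is compound 2, the step of a 5.0-fold higher number from compound 1 to compound 2 (0.70 log units; beyond the scatter) being a modest weakening. Between the two substituted compounds the step of a 7.9-fold lower number from compound 2 to compound 3 (0.90 log units; beyond the scatter) is a modest strengthening.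

Compound 4 `COc1cc2[nH]c(=O)n(CC(N)=O)c2cc1NS(=O)(=O)c1cccc(Cl)c1Cl` differs from compound 1 in one place: carbamoylmethyl in place of hydrogen on an aromatic nitrogen. Among the measured compounds shown here, the steps that bear on it are the two substitutions of the same ring-nitrogen hydrogen, one of which cost potency and the other of which changed nothing beyond the scatter. A carbamoylmethyl group is small and uncharged and carries a donor and an acceptor, as the diol in compound 2 does, yet it is an open chain rather than a branched one, so neither measured step is a close match. A small loss, or no change beyond the scatter, is therefore expected, the step from compound 1 being estimated as a 1.6-fold higher number from compound 1 to compound 4 (0.20 log units; within the scatter). For compound 4 the expected value in this assay is 500 nM, with a range of 150 nM to 1600 nM.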

Compound 4, half-maximal inhibitory concentration: > 31600 nM
Compound 4 was reported as a limit (the forecaster's own chance of this, stated with the estimate: 5%); middle value at least 63-fold (1.80 log units) from the limit.
By their numbers in this assay, from the lowest: compounds 3 and 1 (each within the scatter of the next); then compound 2. At a limit, above all of these: compound 4.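

In this assay compound 4 is reported only as a limit, > 31600 nM. Among the compounds shown here, replacing the hydrogen on this aromatic nitrogen can therefore cost far more than the earlier compounds indicated: an at least 100-fold higher number from compound 1 to compound 4 (2.00 log units; beyond the scatter) is a large step, set against a 5.0-fold higher number from compound 1 to compound 2 (0.70 log units; beyond the scatter) and a 1.6-fold lower number from compound 1 to compound 3 (0.20 log units; within the scatter), so the outcome at this position depends heavily on which group enters and not merely on whether the hydrogen is replaced. Carbamoylmethyl, with only 4 heavy atoms, no ring and no net charge, gives the largest step of the three, which shows that a low count of heavy atoms does not by itself keep a substituent within what this position accepts, and this reading rests on a limit and not on a number: the limit of > 31600 nM in this assay, at which 1 of the 4 values shown sits.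

Still open, as far as these compounds go, is whether the loss belongs to the primary amide or to the open chain that carries it, a question that a plain methyl or ethyl group, a dimethylamide or a methyl ester in the same place would help to separate. Also open, from the compounds shown here alone, is how a carboxylic acid, an amine or a longer chain such as 2-carbamoylethyl would behave on this nitrogen.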